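The compounds below may be only part of what the source reports. "The series", "measured", "known", "first", "only" and "open" are said of these compounds alone.

Measured compounds in a functional assay on WM 266-4 cells (Homo sapiens) for inhibition, read by MTT assay, with a stated time of 24 h; on this read-out higher numbers stand for weaker inhibition of growth and lower numbers for stronger inhibition of growth:
compound 1, `COc1ccc(C2CC(c3ccc(Br)cc3)=NN2C(=O)C2COc3ccccc3O2)cc1`, gives 9010 nM;
compound 2, `O=C(C1COc2ccccc2O1)N1N=C(c2ccc(Br)cc2)CC1c1cccc(F)c1`, gives 7810 nM;
compound 3, `O=C(c1ccc2c(c1)OCCO2)N1N=C(c2ccccc2)CC1c1cccc(F)c1`, gives 1840 nM.

Compound 4, `COc1ccc(C2CC(c3ccccc3)=NN2C(=O)c2ccc3c(c2)OCCO3)cc1`, is not yet measured. It is made from compound 3 by 4-methoxyphenyl in place of 3-fluorophenyl on a saturated ring carbon. The same kind of change has been made once before, as 4-methoxyphenyl in place of 3-fluorophenyl on a saturated ring carbon, and there it gave a 1.2-fold higher number from compound 2 to compound 1 (0.06 log units; within the scatter). The surroundings are not identical: in compound 2 the place lies two ring bonds from the ring atom that bears a 4-bromophenyl group, in compound 3 two ring bonds from the ring atom that bears a phenyl group. How the cores of compound 2 and compound 3 differ is not broken down here. The earlier step stayed within the scatter. On that basis a small step is expected here, a 1.2-fold higher number from compound 3 to compound 4 (0.08 log units; within the scatter). Compound 4 is therefore estimated at 2200 nM, between 1000 nM and 5000 nM.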

Compound 4, concentration for 50% growth inhibition: 8370 nM
For compound 4 the middle estimate is 3.8-fold (0.58 log units) below the measured one; the whole stated range lies below it.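

In this assay, 4-methoxyphenyl in place of 3-fluorophenyl on a saturated ring carbon gives a 4.5-fold higher number from compound 3 to compound 4 (0.66 log units; beyond the scatter), and the size of this step does not carry over from the earlier core: the same change on two cores in this assay, a 1.2-fold higher number (0.06 log units; within the scatter) from compound 2 to compound 1 and a 4.5-fold higher number (0.66 log units; beyond the scatter) from compound 3 to compound 4, 3.9-fold (0.60 log units) apart, beyond the scatter of two such steps In this series, the step measured on one core therefore cannot be taken as the step on the other. The two pairs do not show which part of the cores accounts for the gap, nor how the change behaves on any further core.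

Open, on these data alone, is whether the gap follows the 4-bromophenyl group or another part of the core. Also open, as far as these compounds go, is how an amine or a carboxylic acid in place of the methoxy group would behave on either core.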